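Moving the fluorine on the aryl group of compound 3

The source may hold more compounds than are shown below. What is called first, only, known or untested is meant among the compounds shown, and "the series" means these compounds.

Compound 1 `COc1cc(C2=NN(C(C)=O)C(c3cccc(OC)c3OC)O2)cc(OC)c1OC` gives 17.5% in a functional assay on BGC-823 cells (Homo sapiens) for antiproliferative activity, read by MTT assay, tested at 5 uM; a lower number here means a weaker effect, a higher number a stronger effect of the compound at the concentration tested; compound 2 `COc1cc(C2=NN(C(C)=O)C(c3ccc(Cl)c(Cl)c3)O2)cc(OC)c1OC` gives 3.1%; compound 3 `COc1cc(C2=NN(C(C)=O)C(c3ccccc3F)O2)cc(OC)c1OC` gives 32.8%.

Compound 3 stands highest of the three numbers in this assay: the step of a number 15.3 percentage points higher from compound 1 to compound 3 (beyond the scatter) and the step of a number 29.7 percentage points higher from compound 2 to compound 3 (beyond the scatter) both lie beyond the scatter, and a number 14.4 percentage points lower from compound 1 to compound 2 (beyond the scatter) shows the ring with two chlorines giving the lowest number. Compound 4 `COc1cc(C2=NN(C(C)=O)C(c3cccc(F)c3)O2)cc(OC)c1OC` keeps the same atoms as compound 3, joined differently: 3-fluorophenyl in place of 2-fluorophenyl on a saturated ring carbon. Among the compounds with values here, no measured step moves a fluorine within the aryl ring; the two steps that bear on it exchange the whole aryl group and are modest. A small step is therefore expected for compound 4, estimated as a number 7.8 percentage points lower from compound 3 to compound 4 (within the scatter), and its value in this assay is expected to be 25% with a range from 8% to 42%.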

Compound 4, a percentage reported as inhibition, at one concentration (the size of the read-out at that concentration, not a potency): 37.7%
Estimate against measurement, compound 4: 12.7 percentage points below; measured number inside the range.
By their numbers in this assay, from the lowest: compound 2; then compound 1; then compounds 3 and 4 (each within the scatter of the next).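

In this assay, replacing 2-fluorophenyl with 3-fluorophenyl on the saturated ring carbon gives a number 4.9 percentage points higher from compound 3 to compound 4 (within the scatter), so this move of the fluorine does not separate the two compounds. The 3-fluorophenyl group also stands clear of both other aryl groups, with a number 34.6 percentage points higher from compound 2 to compound 4 (beyond the scatter) and a number 20.2 percentage points higher from compound 1 to compound 4 (beyond the scatter). No evidence shown accounts for these numbers. As far as these compounds go, what an amine or a carboxylic acid in place of the fluorine would give in this assay stays open. From the compounds shown here alone, whether compound 3 and compound 4 also stay together at other concentrations or on other cells stays open too.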